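This account rests on a few compounds, and the source may have more. Where it says the series, first, only, none or still open, it means among the compounds named here.

The measured compounds:
Compound 1, `CC(C(=O)NCc1ccc(Cl)cc1)c1ccc(NS(C)(=O)=O)c(F)c1`, gives 367 nM in a functional assay on CHO cells for antagonist activity at transient receptor potential cation channel subfamily V member 1 (Rattus norvegicus); a higher number here means a weaker inhibitor, a lower number a stronger inhibitor.
Compound 2, `CC(C)c1ccc(CNC(=O)C(C)c2ccc(NS(C)(=O)=O)c(F)c2)cc1`, gives 144 nM in this assay.
Compound 3, `CC(C(=O)NCc1ccc(C2CC2)cc1)c1ccc(NS(C)(=O)=O)c(F)c1`, gives 55.5 nM in this assay.

Compound 3 holds the lowest number of the three; compound 2 stands nearest to it and compound 1 furthest, and both gaps, a 2.6-fold lower number from compound 2 to compound 3 (0.41 log units; beyond the scatter) and a 6.6-fold lower number from compound 1 to compound 3 (0.82 log units; beyond the scatter), lie beyond the scatter. Compound 4, `CC(C(=O)NCc1ccc(C2CCCC2)cc1)c1ccc(NS(C)(=O)=O)c(F)c1`, keeps the shared core of compound 3 and is altered only at the aromatic carbon: cyclopentyl in place of cyclopropyl on an aromatic carbon. Among the compounds with values here, the steps that bear on this position are a 2.5-fold lower number from compound 1 to compound 2 (0.41 log units; beyond the scatter), a 6.6-fold lower number from compound 1 to compound 3 (0.82 log units; beyond the scatter) and a 2.6-fold lower number from compound 2 to compound 3 (0.41 log units; beyond the scatter); every exchange at this carbon has shifted the number by a modest amount, and the three-membered ring has given the lowest number so far. A five-membered ring at this carbon has not been measured, so the direction of the next step is open. Compound 4 is expected to give about 90 nM in this assay, within 30 nM to 280 nM. The expected step is therefore small, close to the scatter: a 1.6-fold higher number from compound 3 to compound 4 (0.21 log units; within the scatter).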

Compound 4, inhibition constant: 20.8 nM
Compound 4: the middle estimate sits 4.3-fold (0.64 log units) above what was measured; the whole stated range lies above it.
By their numbers in this assay, from the lowest: compound 4; then compound 3; then compound 2; then compound 1.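

The exchange of cyclopropyl for cyclopentyl on the aromatic carbon gives a 2.7-fold lower number from compound 3 to compound 4 (0.43 log units; beyond the scatter), which shows that the three-membered ring does not mark the lowest number reachable at this position and that a larger carbon ring is tolerated in this assay. Within the data shown here, compound 4 now stands as the strongest inhibitor of the four, with a 6.9-fold lower number from compound 2 to compound 4 (0.84 log units; beyond the scatter) and an 18-fold lower number from compound 1 to compound 4 (1.25 log units; beyond the scatter), the latter the only large step at this carbon. Nothing among the data given accounts for the drop seen with the five-membered ring.

The compounds shown leave open whether cyclohexyl or a phenyl ring at this carbon would lower the number further. They also leave open whether the five-membered ring would keep its value with an oxygen in it, as in tetrahydrofuranyl.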